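This account rests on a few compounds, and the source may have more. Where it says the series, first, only, none or still open, it means among the compounds named here.

Measured so far in a functional assay on MCF7 cells (Homo sapiens) for inhibition, read by CCK-8 assay, with a stated time of 48 h; on this read-out lower numbers stand for stronger inhibition and higher numbers for weaker inhibition:
Compound 1 `COc1cc(-c2ccnc3cc(-c4ccc5c(ccn5C)c4)nn23)cc(OC)c1OC`: 3 nM
Compound 2 `COc1cc(-c2ccnc3cc(-c4ccc5ccn(C)c5c4)nn23)cc(OC)c1OC`: 74 nM
Compound 3 `COc1ccc(-c2cc3nccc(-c4cc(OC)c(OC)c(OC)c4)n3n2)cc1`: 125 nM

Compound 3 is the starting point here. The step of a 42-fold higher number from compound 1 to compound 3 (1.62 log units; beyond the scatter) is large, while the step of a 1.7-fold higher number from compound 2 to compound 3 (0.23 log units; within the scatter) lies within the scatter, so those last two cannot be ranked.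

Compound 4 `COc1ccc(-c2cc3nccc(-c4cc(OC)c(OC)c(OC)c4)n3n2)cc1F` keeps all of compound 3 except for one hydrogen on the 4-methoxyphenyl group, which fluoro replaces to give 3-fluoro-4-methoxyphenyl: fluoro in place of hydrogen on an aromatic carbon. Going by the values given here, no measured step tests a change of this kind. Each one exchanges a whole group, and the step of a 25-fold higher number from compound 1 to compound 2 (1.39 log units; beyond the scatter) shows that such an exchange can matter greatly in this assay. Here only a single atom changes on a group that otherwise stays, so those steps offer a caution rather than a size. No step beyond the scatter is expected, though the range is kept wide. The expected step is a 1.3-fold lower number from compound 3 to compound 4 (0.10 log units; within the scatter). The estimated value for compound 4 is 100 nM, with an expected range from 30 nM to 350 nM.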

Compound 4, half-maximal inhibitory concentration: 183 nM
Compound 4: the middle estimate sits 1.8-fold (0.26 log units) below what was measured; the range from low to high includes it.
By their numbers in this assay, from the lowest: compound 1; then compounds 2, 3 and 4 (each within the scatter of the next, the first and the last beyond it).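

In this assay, putting fluoro in place of hydrogen, ortho to a methoxy group on the 4-methoxyphenyl ring, gives a step within the scatter (a 1.5-fold higher number from compound 3 to compound 4 (0.17 log units; within the scatter)), so this single-atom change cannot be told apart from no change. The 3-fluoro-4-methoxyphenyl group stays clearly behind both indole groups, modestly behind one (a 2.5-fold higher number from compound 2 to compound 4 (0.39 log units; beyond the scatter)) and far behind the other (a 61-fold higher number from compound 1 to compound 4 (1.79 log units; beyond the scatter)), so fluoro here does not close the large gap to the 1-methyl-1H-indol-5-yl group. Nothing measured here explains this result.

From the compounds shown here alone, it remains open whether fluoro on the 1-methyl-1H-indol-5-yl group of compound 1 would be equally silent. Going by these compounds, it is also open what a larger or charged group, such as an amine or a carboxylic acid, would do where the fluoro sits in compound 4.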